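Methyl added to compound 3: expectation for compound 4

A few compounds are considered here, and "the series" means these few. Any claim that something is new, unique, unknown or untested is made for them only; others in the source may bear on it.

Three compounds of the series share one core and differ only in the substituent on that core. Compound 1 `CN1CCN(c2ccn3c(-c4ccc(NC(=O)c5ccc([N+](=O)[O-])o5)cc4)cnc3c2)CC1` gives 1580 nM in a functional assay on MGC-803 cells (Homo sapiens) for antiproliferative activity, read by CCK-8 assay, with a stated time of 72 h; on this read-out higher numbers stand for weaker inhibition and lower numbers for stronger inhibition. Compound 2 `O=C(Nc1ccc(-c2cnc3cc(Br)ccn23)cc1)c1ccc([N+](=O)[O-])o1` gives 750 nM in this assay, and compound 3 `COc1ccn2c(-c3ccc(NC(=O)c4ccc([N+](=O)[O-])o4)cc3)cnc2c1` gives 860 nM in this assay. The step of a 2.1-fold lower number from compound 1 to compound 2 (0.32 log units; beyond the scatter) lies beyond the scatter, whereas the steps of a 1.8-fold lower number from compound 1 to compound 3 (0.26 log units; within the scatter) and a 1.1-fold higher number from compound 2 to compound 3 (0.06 log units; within the scatter) do not. Compound 3 thus stands second highest of the three numbers, close to compound 2 and not separated from compound 1 beyond the scatter.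

Compound 4 `COc1ccn2c(-c3ccc(NC(=O)c4ccc([N+](=O)[O-])o4)cc3C)cnc2c1` differs from compound 3 by methyl in place of hydrogen on an aromatic carbon. Within the data shown here, none of the measured steps touches this place: all three concern the substituent on the core, and none of them adds a methyl anywhere. Among the measured compounds shown here, no measured step bears on the change, so there is no basis for expecting a shift beyond the scatter in either direction, and the expectation rests on the narrow spread of the three known numbers around the value of compound 3.

For compound 4 the expected value in this assay is 860 nM, with a range from 300 nM to 2500 nM. The step of no change at the digits printed from compound 3 to compound 4 (within the scatter) is accordingly expected to stay within the scatter.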

Compound 4, half-maximal inhibitory concentration: 1030 nM
Compound 4: middle estimate off by 1.2-fold (0.08 log units), on the low side; the measured number falls inside the stated range.
By their numbers in this assay, from the lowest: compounds 2, 3, 4 and 1 (each within the scatter of the next, the first and the last beyond it).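

In this assay, methyl in place of hydrogen on an aromatic carbon of a six-membered aromatic ring of carbon only, ortho to a large group and meta to a large group, gives a 1.2-fold higher number from compound 3 to compound 4 (0.08 log units; within the scatter) and so stays within the scatter. Among these compounds, this is the only step that touches this ring, as the earlier steps all concern the substituent on the shared core, and it shows that this carbon can carry a methyl without a shift beyond the scatter, at least with the methoxy of compound 3 on the core. No measurement at hand offers an explanation for this result, so the step stands as an observation only.

Going by these compounds, whether this carbon accepts more than a single methyl remains open: a longer chain such as propyl, an amine or a carboxylic acid in the same place could give a different number. Among the compounds shown here, it is also open whether the methyl would have the same outcome alongside the bromo of compound 2 or the 4-methylpiperazin-1-yl of compound 1, since the only pair at this position carries methoxy on the core.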